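The compounds below may be only part of what the source reports. "The series", "measured", "known", "first", "only" and "open" are said of these compounds alone.

Compound 1 `CN(C)CCCCOC(=O)Nc1ccc(Cn2nc(-c3cncnc3)c3ccccc3c2=O)cc1` and compound 2 `CN(C)CCCCOC(=O)Nc1ccc(Cn2nc(-c3cnn(C)c3)c3ccccc3c2=O)cc1` share one core and differ only in the aromatic group attached to it. In an ADME assay on Huh-7 cells (Homo sapiens) for cytotoxicity, read by MTT assay, with a stated time of 48 h (on this read-out lower numbers stand for higher toxicity in this test and higher numbers for lower toxicity in this test), compound 1 gives 65300 nM, and compound 2 gives 55900 nM. On these two numbers compound 2 stands beside compound 1, the pair being within the scatter, as the step of a 1.2-fold lower number from compound 1 to compound 2 (0.07 log units; within the scatter) shows. Compound 3 `CN(C)CCCCOC(=O)Nc1ccc(Cn2nc(-c3ccccc3)c3ccccc3c2=O)cc1` carries the same kind of exchange: phenyl in place of 1-methyl-1H-pyrazol-4-yl on an aromatic carbon. Among the measured compounds shown here, the only comparable step stayed within the scatter, so no shift beyond the scatter is expected here either. Compound 3 is therefore estimated at 60000 nM, within 30000 nM to 120000 nM. The expected step is a 1.1-fold higher number from compound 2 to compound 3 (0.03 log units; within the scatter).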

Compound 3, half-maximal cytotoxic concentration: 16000 nM
For compound 3 the middle estimate is 3.8-fold (0.57 log units) above the measured one, outside the stated range (below it).
By their numbers in this assay, from the lowest: compound 3; then compounds 2 and 1 (each within the scatter of the next).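

In this assay, the group at this position can matter: a 3.5-fold lower number from compound 2 to compound 3 (0.54 log units; beyond the scatter) and a 4.1-fold lower number from compound 1 to compound 3 (0.61 log units; beyond the scatter) both lie beyond the scatter, whereas the exchange of pyrimidin-5-yl for 1-methyl-1H-pyrazol-4-yl did not. Of the three groups, only phenyl, with its aromatic ring of carbon only, stands apart, on the side of higher toxicity in this test. Still open, from the compounds shown here alone, is whether a cyclohexyl ring, or a phenyl ring carrying a fluorine or a methoxy group, would side with phenyl or with the two nitrogen-containing rings. No measurement on the cause of this shift is at hand.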